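Swapping a Fluorophenyl Ring for Thiophene: Expected Lipophilicity

The source may hold more compounds than are shown below. What is called first, only, known or untested is meant among the compounds shown, and "the series" means these compounds.

Compound 1 `O=C(NNc1ccnc2cc(Cl)ccc12)c1ccccc1/N=C/c1ccc(F)cc1` is the most polar of the three measured compounds in a physicochemical assay for lipophilicity, measured as octanol-water partition (a higher number here means a more lipophilic compound, a lower number a more polar compound), where compound 1 gives 5.18. Compound 2 `O=C(NNc1ccnc2cc(Cl)ccc12)c1ccccc1/N=C/c1cccc(Cl)c1Cl` gives 6.1, and compound 3 `O=C(NNc1ccnc2cc(Cl)ccc12)c1ccccc1/N=C/c1ccc(Cl)c(Cl)c1` gives 6.22. The steps upward from the starting point are a number 0.92 log units higher from compound 1 to compound 2 (beyond the scatter) and a number 1.04 log units higher from compound 1 to compound 3 (beyond the scatter), while the remaining step, a number 0.12 log units higher from compound 2 to compound 3 (within the scatter), stays within the scatter.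

Compound 4 `O=C(NNc1ccnc2cc(Cl)ccc12)c1ccccc1/N=C/c1cccs1` has not yet been measured. It differs from compound 1 in one place: thiophen-2-yl in place of 4-fluorophenyl on a carbon with a double bond to nitrogen. For the measured compounds named here, none of the measured steps makes this same change; each of them adds chlorine atoms to a six-membered ring on that carbon and raises this assay, so they show only that the number here moves with what is attached at this position. The entering group is a five-membered aromatic ring with 1 hetero atom and fewer heavy atoms than the 4-fluorophenyl it replaces, so a downward step from compound 1 is expected, of modest size and possibly within the scatter. The expected step is a number 0.43 log units lower from compound 1 to compound 4 (beyond the scatter). For compound 4 the estimate in this assay is 4.75, with a range from 4.3 to 5.2.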

Compound 4, partition coefficient: 4.78
Compound 4: middle estimate off by 0.03 log units, on the low side, within the range that was stated.
By their numbers in this assay, from the lowest: compound 4; then compound 1; then compounds 2 and 3 (each within the scatter of the next).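

In this assay, for the compounds shown here, the earlier steps at this position all raised the number, whereas thiophen-2-yl gives the first step down, a number 0.40 log units lower from compound 1 to compound 4 (beyond the scatter), so the number at this carbon can move in both directions. Measured against the two dichlorophenyl compounds, the same ring gives much wider gaps, a number 1.32 log units lower from compound 2 to compound 4 (beyond the scatter) and a number 1.44 log units lower from compound 3 to compound 4 (beyond the scatter), and compound 4 now marks the low end of the series, with the dichlorophenyl groups at the high end and 4-fluorophenyl in between. No measurement available here explains what lies behind these steps.

The step from compound 1 to compound 4 changes several things at once: a six-membered aromatic ring of carbon only becomes a five-membered one, sulfur enters, and fluorine leaves, so the compounds shown cannot separate these changes. Plain phenyl would isolate the loss of fluorine, while furan-2-yl or thiophen-3-yl would test whether the step depends on the sulfur atom or on where the ring is attached, and a ring carrying an amine or a carboxylic acid would show how far the number can fall at this position.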